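A few compounds are considered here, and "the series" means these few. Any claim that something is new, unique, unknown or untested is made for them only; others in the source may bear on it.

Values in a functional assay on KB cells (Homo sapiens) for inhibition, read by MTT assay, with a stated time of 24 h, tested at 100 ug/mL; on this read-out lower numbers stand for less inhibition of growth and higher numbers for more inhibition of growth at the one concentration tested:

- compound 1 `O=C(CCCCC(S)CCS)NO`: 58%
- compound 2 `O=C(CCCCC1CCSS1)Nc1ccccc1Cl`: 0.72%
- compound 3 `O=C(CCCCC(S)CCS)Nc1ccccc1`: 15.8%

In this assay compound 3 stands second of the three, with 15.8% beyond the scatter from both other values.

Compound 4 `O=C(CCCCC(S)CCS)Nc1ccccc1Cl` is reached from compound 3 through chloro in place of hydrogen on an aromatic carbon in one change: chloro in place of hydrogen on an aromatic carbon, ortho to a large group.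

Among the measured compounds shown here, the only measured step, a number 42.2 percentage points lower from compound 1 to compound 3 (beyond the scatter) and large, is a change at the amide-type nitrogen and does not test chloro on the aromatic ring. Compound 2 gives 0.72% and carries chloro too, but the other end of its chain differs from that of compound 4. For the measured compounds named here, no measured pair isolates the chloro change, so neither direction is favoured and no step beyond the scatter is expected.

The estimate is a number 1.8 percentage points lower from compound 3 to compound 4 (within the scatter) in this assay and the range stays wide.

For compound 4 the expected value is 14% within an estimated range from 3% to 30% in this assay as read here.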

Compound 4, percent growth inhibition at one concentration: "not active" (no number reported)
For compound 4 the study gives words and no number; there is nothing to compare the estimate with.
By their numbers in this assay, from the lowest: compound 2; then compound 3; then compound 1.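

Among the compounds shown here, compound 4 is reported only in words, as not active, without a number, so no step from compound 3 to compound 4 can be read. No evidence at hand bears on this result. For the compounds shown here, the size of the effect of chloro in place of hydrogen on an aromatic carbon stays open: no pair of numbers isolates that change.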